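Replacing the nitrogen substituent of compound 3

The compounds below may be only part of what the source reports. "The series", "measured", "known", "first", "only" and "open" are said of these compounds alone.

In a physicochemical assay for lipophilicity, read by HPLC, at pH 7.5 (on this read-out lower numbers stand for lower lipophilicity and higher numbers for higher lipophilicity), compound 3 `CCOc1ccccc1-c1ccc(-c2nc3cnccc3c(N[C@H](CC)C(=O)NS(=O)(=O)C3CC3)c2C#N)cc1` gives 2.3. Compound 2 `CCOc1ccccc1-c1ccc(-c2nc3cnccc3c(NC(C)C(=O)O)c2C#N)cc1` gives 2.1, within the scatter of compound 3, while compound 1 `CC[C@@H](Nc1c(C#N)c(-c2ccc(-c3ccccc3F)cc2)nc2cnccc12)C(N)=O` gives 2.7, beyond the scatter above compound 3.

The next structure is compound 4 `CCCCC(Nc1c(C#N)c(-c2ccc(-c3ccccc3OCC)cc2)nc2cnccc12)C(N)=O`, with this change: a group of 8 heavy atoms (6 carbon, 1 nitrogen, 1 oxygen; no ring) in place of a group of 12 heavy atoms (7 carbon, 1 nitrogen, 3 oxygen, 1 sulfur; one three-membered non-aromatic ring of carbon only), on a nitrogen on an aromatic ring. The entering group is 1-carbamoylpentyl. Among the measured compounds shown here, the only measured step at this place is a number 0.20 log units higher from compound 2 to compound 3 (within the scatter). It exchanged a different pair of groups, so it offers little guidance on size or direction here. A closer guide is compound 1, which also carries a carbamoyl group on its substituent and gives 2.7, although its chain is shorter and it differs elsewhere too. That value points upward, so a rise beyond the scatter is expected. The estimated change is a number 1.20 log units higher from compound 3 to compound 4 (beyond the scatter). For compound 4 the expected value is 3.5, within an estimated range from 2.9 to 4.1.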

Compound 4, distribution coefficient: 3.6
For compound 4 the middle estimate is 0.10 log units below the measured one, within the range that was stated.
By their numbers in this assay, from the lowest: compounds 2 and 3 (each within the scatter of the next); then compound 1; then compound 4.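

In this assay, among the compounds shown here, putting 1-carbamoylpentyl on this nitrogen gives a number 1.30 log units higher from compound 3 to compound 4 (beyond the scatter) and is the first step at this place to lie beyond the scatter. Replacing 1-carboxyethyl with the same group gives a number 1.50 log units higher from compound 2 to compound 4 (beyond the scatter) and confirms that this substituent can move the read-out strongly. The entering group has fewer heavy atoms than the group it replaces in compound 3, yet compound 4 reads highest of the three compounds that differ here, so the order does not follow heavy-atom count.

Still open, on these data alone, is whether the rise belongs to the carbamoyl group or to the chain, and how a pentyl chain ending in a carboxylic acid or an amine would read on the core of compound 4. The data at hand give no cause for these steps.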